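This account rests on a few compounds, and the source may have more. Where it says the series, first, only, none or still open, it means among the compounds named here.

Measured so far:
compound 1, `CS/C(=N\C(=O)c1ccno1)NC(=O)c1ccno1` — > 100000 nM
compound 2, `O=C(/N=C(/NC(=O)c1ccno1)[Se]Cc1ccccc1)c1ccno1` — 94700 nM

For the measured compounds named here, compound 2 is the only compound that gives a number in a functional assay on K562 cells (Homo sapiens) for cytotoxicity, read by MTT assay, with a stated time of 72 h; a lower number here means that less compound is tolerated, a higher number that more compound is tolerated: compound 2 gives 94700 nM. For compound 1 the assay reports only a limit, > 100000 nM. Going by the values given here, the one measured step, an at least 1.0-fold lower number from compound 1 to compound 2 (0.02 log units; that floor lies within the scatter), is therefore bounded by the limit of > 100000 nM in this assay, at which 1 of the 2 values shown sits, and lies within the usual scatter.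

Compound 3 is `C[Se]/C(=N\C(=O)c1ccno1)NC(=O)c1ccno1`. It differs from compound 2 by hydrogen in place of phenyl on a saturated chain carbon bound to a selenium atom. Among the compounds with values here, no measured step here touches this kind of change; the only step on record, which replaced a small sulfur group by the larger benzylseleno group, moved the number little. The expectation for compound 3 is thus a step of about a 1.2-fold higher number from compound 2 to compound 3 (0.07 log units; within the scatter), no larger than the scatter, in this assay. The estimated value for compound 3 is 110000 nM, with a range from 40000 nM to 300000 nM, and a real chance that only a limit is reported.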

Compound 3, concentration lethal to 50% of the cells: > 100000 nM
Compound 3 ended at the assay's limit; the forecaster's own chance of this, stated with the estimate: 50%; the middle value is on the limit's open side.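

Replacing phenyl with hydrogen, which turns benzyl into methyl on the selenium atom, gives an at least 1.0-fold higher number from compound 2 to compound 3 (0.02 log units; that floor lies within the scatter) in this assay. At this position, losing the six-membered aromatic ring therefore produces no readable change, but this step is only a floor and does not show how far apart the two compounds truly lie. The step from compound 1 to compound 3, which exchanges sulfur for selenium, cannot be read, and the reason for this limited view is a shared ceiling: the limit of > 100000 nM in this assay, at which 2 of the 3 values shown sit.

The compounds shown leave open whether any group on the selenium atom can bring the number clearly inside the measurable range. A longer chain, an amine or a carboxylic acid in place of benzyl or methyl would test this.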